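Cyclobutyl for ethyl on the piperazine nitrogen of compound 2

The source may hold more compounds than are shown below. What is called first, only, known or untested is meant among the compounds shown, and "the series" means these compounds.

Of the compounds shown here, two have been measured in an assay on HEK293 cells for inhibition of potassium/sodium hyperpolarization-activated cyclic nucleotide-gated channel 4 (Homo sapiens), with a stated time of 30 min; on this read-out higher numbers stand for weaker inhibition and lower numbers for stronger inhibition. Compound 1 `CC(C)Oc1ccccc1C(=O)NCC1(N2CCN(C(C)C)CC2)CCCCC1` gives 1580 nM in this assay. Compound 2 `CCOc1ccccc1C(=O)NCC1(N2CCN(CC)CC2)CCCCC1` gives 158 nM in this assay, the lower of the two numbers, with compound 1 standing well beyond the usual scatter above it. Compound 1 and compound 2 differ in two places at once, so their two values alone are what can be said of that pair.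

Compound 3 `CCOc1ccccc1C(=O)NCC1(N2CCN(C3CCC3)CC2)CCCCC1` has not yet been measured. It differs from compound 2 in one place: cyclobutyl in place of ethyl on an amine nitrogen in a ring. Among the measured compounds shown here, no single-change step between measured compounds is available to calibrate this exchange, and the one measured pair does not isolate the group on the ring nitrogen. The expectation is therefore a modest step from compound 2 to compound 3 of a 1.9-fold higher number from compound 2 to compound 3 (0.28 log units; within the scatter) in this assay, toward a somewhat higher number, with the outcome plausibly within the scatter. Compound 3 is accordingly estimated at 300 nM in this assay, with a likely range from 100 nM to 1000 nM.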

Compound 3, half-maximal inhibitory concentration: 794 nM
Compound 3: middle estimate off by 2.6-fold (0.42 log units), on the low side; low and high end bracket the measured number.
By their numbers in this assay, from the lowest: compound 2; then compounds 3 and 1 (each within the scatter of the next).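

In this assay, among the compounds shown here, cyclobutyl in place of ethyl on the amine nitrogen in the ring gives the first single-change step, a 5.0-fold higher number from compound 2 to compound 3 (0.70 log units; beyond the scatter), and this step lies beyond the scatter. It shows that the group on this nitrogen matters: with the rest of compound 2 unchanged, replacing a group of 2 heavy atoms with a four-membered carbon ring of 4 heavy atoms leads to weaker inhibition. Nothing in the data explains this loss, so it stands as an observation from one pair of compounds.

From the compounds shown here alone, whether methyl or a plain hydrogen on this nitrogen would give a lower number than ethyl remains open, as does whether cyclopropyl or a longer chain such as propyl would behave more like ethyl or more like cyclobutyl. The effect of the other group that varies in the series also remains unresolved, since compound 1 differs from compound 2 in two places at once, and a methoxy group in place of the ethoxy group of compound 2 would be one way to examine that position alone.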